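This account rests on a few compounds, and the source may have more. Where it says the series, first, only, none or still open, it means among the compounds named here.

Measured in a functional assay on the whole organism with Mus musculus as the target; on this read-out higher numbers stand for an effect only at larger amounts of compound and lower numbers for an effect already at smaller amounts:
- Compound 1 `C[C@@H](NCc1ccc(OCc2ccccc2)cc1)C(N)=O`: 23.8 mg/kg
- Compound 2 `CNC(=O)[C@@H](C)NCc1ccc(OCc2ccccc2)cc1`: 40.5 mg/kg
- Compound 3 `CNC(=O)[C@@H](NCc1ccc(OCc2ccccc2)cc1)C(C)C`: 55.4 mg/kg

Compound 1 sits at the low end of this small set, though not clearly apart from compound 2, as a 1.7-fold higher number from compound 1 to compound 2 (0.23 log units; within the scatter) shows. Only compound 3 separates from it, with a 2.3-fold higher number from compound 1 to compound 3 (0.37 log units; beyond the scatter). The remaining step, a 1.4-fold higher number from compound 2 to compound 3 (0.14 log units; within the scatter), adds little.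

Compound 4 `C[C@@H](NCc1ccc(OCc2ccccc2Cl)cc1)C(N)=O` keeps the core of compound 1 and carries chloro in place of hydrogen on an aromatic carbon, ortho to a large group, so that phenyl becomes 2-chlorophenyl: chloro in place of hydrogen on an aromatic carbon. Among the compounds with values here, none of the measured steps touches this part of the molecule. All three are changes on an amide-type nitrogen or an amine nitrogen, so they bear on the question only indirectly, by showing that changes elsewhere moved the number little or modestly. Within the data shown here, the data hold no example of a chloro group, and they give no direction for this change. No step beyond the scatter is therefore expected in this assay, though the uncertainty is wide. The expected outcome is a 1.2-fold lower number from compound 1 to compound 4 (0.08 log units; within the scatter), an estimated step that stays within the scatter. For compound 4 the estimated value is 20 mg/kg, with an expected range from 9 mg/kg to 45 mg/kg.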

Compound 4, dose for half-maximal effect: 17.4 mg/kg
Estimate against measurement, compound 4: 1.1-fold (0.06 log units) above, and the stated range covers the measured number.
By their numbers in this assay, from the lowest: compounds 4, 1, 2 and 3 (each within the scatter of the next, the first and the last beyond it).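

Within the data shown here, compound 4 gives the first look at the terminal phenyl, a part of the molecule that none of the earlier steps touched: in this assay, chloro in place of hydrogen on an aromatic carbon, ortho to a large group, gives a 1.4-fold lower number from compound 1 to compound 4 (0.14 log units; within the scatter). Phenyl and 2-chlorophenyl therefore cannot be told apart on this read-out, which shows that this one added chlorine atom at this place leaves the dose for half-maximal effect in the same range as that of the parent, with no clear gain or loss on either side. No measurement shown here offers any explanation for this result.

On these data alone, what remains open is whether a fluoro, bromo or methoxy group at the same place would also stay within the scatter of compound 1, and whether chloro on another aromatic carbon of that ring would read the same way. As far as these compounds go, it is also open whether chloro on the terminal ring would hold up when combined with the methyl on the amide nitrogen of compound 2, or with the larger 2-methyl-1-(methylcarbamoyl)propyl group of compound 3.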